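The compounds below may be only part of what the source reports. "The series", "measured", "known", "first", "only" and "open" are said of these compounds alone.

The series shares one core, and its compounds were tested in an ADME assay on MT4 cells (Homo sapiens) for cytotoxicity, read by MTT assay; on this read-out higher numbers stand for lower toxicity in this test and lower numbers for higher toxicity in this test. Compound 2 `O=C(CSc1nncnc1-c1cccc2ccccc12)Nc1ccccc1Br` gives 87000 nM in this assay, the higher of the two numbers recorded so far. Compound 3 `COC(=O)c1ccc(NC(=O)CSc2nncnc2-c2ccccc2Cl)c(Br)c1` gives 59000 nM in this assay, a value that sits within the scatter of the number for compound 2, so no order between these two can be read. For compound 1 `O=C(CSc1nncnc1-c1ccccc1Cl)N1CCc2ccccc2C1` the result in this assay is reported as a limit rather than a number, >= 38000 nM, namely (the limit of >= 38000 nM in this assay, at which 1 of the 3 values shown sits). Compound 4 `Cc1ccc(NC(=O)CSc2nncnc2-c2cccc3ccccc23)c([N+](=O)[O-])c1` has not yet been measured in this assay. It differs from compound 2 in one place: 4-methyl-2-nitrophenyl in place of 2-bromophenyl on an amide-type nitrogen. Within the data shown here, no step between two measured compounds is available to size this change, and the two numbers recorded lie close together. In this assay compound 4 is therefore expected to give 70000 nM, with a range from 30000 nM to 160000 nM. This amounts to an expected step of a 1.2-fold lower number from compound 2 to compound 4 (0.09 log units; within the scatter), nothing beyond the scatter.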

Compound 4, half-maximal cytotoxic concentration: 147000 nM
For compound 4 the middle estimate is 2.1-fold (0.32 log units) below the measured one; the range from low to high includes it.
By their numbers in this assay, from the lowest: compounds 3, 2 and 4 (each within the scatter of the next, the first and the last beyond it).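

Among these compounds, on an amide-type nitrogen whose other neighbour is the carbonyl carbon, this assay now gives a first sized step for this place: a 1.7-fold higher number from compound 2 to compound 4 (0.23 log units; within the scatter), with 4-methyl-2-nitrophenyl in place of 2-bromophenyl, and this step lies within the scatter. The earlier compounds shown here offered no step at all, whereas this pair shows that replacing the bromine-bearing ring with a larger one, which carries a methyl group and a nitro group, leaves the read-out indistinguishable in this test. As far as these compounds go, it remains open whether an aliphatic amine, a carboxylic acid or a longer alkyl chain in place of these aromatic groups on that nitrogen would take the number beyond the scatter. Nothing measured here accounts for the size of this step.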